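Swapping the halogen-bearing ring in a pyrazoline thiourea series

This account rests on a few compounds, and the source may have more. Where it says the series, first, only, none or still open, it means among the compounds named here.

Compound 1 `S=C(Nc1ccccc1)N1N=C(c2ccc(Cl)cc2)CC1c1ccc2c(c1)OCCO2` was tested in a functional assay on WM 266-4 cells (Homo sapiens) for antiproliferative activity, read by MTT assay, with a stated time of 48 h; on this read-out higher numbers stand for weaker inhibition of growth and lower numbers for stronger inhibition of growth. In this assay compound 1 gives only a limit, > 200000 nM, so its true value is not known as a number. Compound 2 `Cc1ccc(C2=NN(C(=S)Nc3ccccc3)C(c3ccc4c(c3)OCCO4)C2)cc1` gives 10300 nM. Compound 3 `FC(F)(F)c1ccc(C2=NN(C(=S)Nc3ccccc3)C(c3ccc4c(c3)OCCO4)C2)cc1` gives 52400 nM. Both changes at that aromatic carbon lowered the number: an at least 19-fold lower number from compound 1 to compound 2 (1.28 log units; beyond the scatter) and an at least 3.8-fold lower number from compound 1 to compound 3 (0.58 log units; beyond the scatter). Compound 4 `S=C(Nc1ccccc1)N1N=C(c2ccccc2Br)CC1c1ccc2c(c1)OCCO2` differs from compound 1 by 2-bromophenyl in place of 4-chlorophenyl on a carbon with a double bond to nitrogen. Among the compounds with values here, no measured step covers a bromo group or a change of position, but each measured step away from compound 1 went downward, and compound 1 sits at the limit of > 200000 nM in this assay, at which 1 of the 3 values shown sits. Compound 4 is therefore estimated at 50000 nM, with a range from 10000 nM to 200000 nM; the expected step is an at least 4.0-fold lower number from compound 1 to compound 4 (0.60 log units; beyond the scatter).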

Compound 4, concentration for 50% growth inhibition: > 200000 nM
Compound 4: only a limit was reported; the forecaster's own chance of this, stated with the estimate: 35%; middle value at least 4.0-fold (0.60 log units) away from the limit.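

In this assay compound 4 gives only a limit, > 200000 nM, and its step from compound 1 cannot be read. Against the two compounds with numerical values, 2-bromophenyl gives an at least 3.8-fold higher number from compound 3 to compound 4 (0.58 log units; beyond the scatter) and an at least 19-fold higher number from compound 2 to compound 4 (1.28 log units; beyond the scatter), so this position does not accept every substituted phenyl group equally. Among the compounds shown, compound 1 and compound 4, the two bearing a halogen atom directly on this ring, now share the same limit: the limit of > 200000 nM in this assay, at which 2 of the 4 values shown sit.

The bromo group and its ring position change together here, so neither can be judged alone. On these data alone, how 4-bromophenyl, or a phenyl ring bearing an amine or a carboxylic acid, would behave remains open.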